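Adding a benzyloxy group to the central phenyl ring

A few compounds are considered here, and "the series" means these few. Any claim that something is new, unique, unknown or untested is made for them only; others in the source may bear on it.

Compound 1 `Cc1cc(O)c(C(=O)/C=C/c2ccc(F)cc2)c(-c2ccccc2)c1C(=O)/C=C/c1ccc(F)cc1` is the weaker of two measured members of this small series in a functional assay on MDA-MB-231 cells (Homo sapiens) for cytotoxicity, read by MTT assay, with a stated time of 24 h (on this read-out lower numbers stand for stronger inhibition and higher numbers for weaker inhibition), though its margin is not meaningful: in this assay compound 1 gives 20000 nM, and compound 2 `Cc1cc(O)c(C(=O)/C=C/c2ccc(OCc3ccccc3)cc2)c(-c2ccccc2)c1C(=O)/C=C/c1ccc(OCc2ccccc2)cc1` gives 10000 nM, a gap that sits within the usual scatter. Compound 3 `Cc1cc(O)c(C(=O)/C=C/c2ccc(F)cc2)c(-c2ccc(OCc3ccccc3)cc2)c1C(=O)/C=C/c1ccc(F)cc1` carries the change (benzyloxy in place of hydrogen on an aromatic carbon), benzyloxy in place of hydrogen on an aromatic carbon, para to a large group. Within the data shown here, no measured pair isolates that change, so the expected step is uncertain. Compound 2 shows that benzyloxy groups elsewhere on the molecule leave the number in the same weak range as compound 1, so compound 3 is expected to remain weak as well, with a step of a 1.4-fold lower number from compound 1 to compound 3 (0.15 log units; within the scatter) that is expected to fall within the scatter rather than beyond it. Compound 3 is therefore estimated at 14000 nM, expected to lie between 4500 nM and 45000 nM.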

Compound 3, half-maximal inhibitory concentration: 15000 nM
For compound 3 the middle estimate is 1.1-fold (0.03 log units) below the measured one; the range from low to high includes it.
By their numbers in this assay, from the lowest: compounds 2, 3 and 1 (each within the scatter of the next).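

Among these compounds, compound 1 and compound 3 form the first pair that differ in one place, so the change of benzyloxy in place of hydrogen on an aromatic carbon, para to a large group, can now be read on its own. In this assay, among the compounds shown here, the change gives a 1.3-fold lower number from compound 1 to compound 3 (0.12 log units; within the scatter) and so adds a whole extra six-membered aromatic ring at this position with no step that can be told apart from repeat-measurement noise. Nothing available explains why the number holds steady here.

As far as these compounds go, whether an amine or a carboxylic acid at the same position would give a step beyond the scatter remains open. From the compounds shown here alone, it is also open whether a shorter group such as methoxy would behave as benzyloxy does here.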